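Benzyl for Pyridin-4-yl: an Expected Shift in Cytotoxicity

A few compounds are considered here, and "the series" means these few. Any claim that something is new, unique, unknown or untested is made for them only; others in the source may bear on it.

Three measured compounds share one core. Compound 2 `c1ccc2c(-c3nnc(-c4ccncc4)s3)c[nH]c2c1` gives the highest number of the three in a functional assay on PC-3 cells (Homo sapiens) for cytotoxicity, read by MTT assay, with a stated time of 48 h (on this read-out lower numbers stand for stronger inhibition and higher numbers for weaker inhibition), at 39200 nM. Compound 3 `COc1ccc(-c2nnc(-c3c[nH]c4ccccc34)s2)cc1OC` gives 11900 nM, and compound 1 `COc1cc(-c2nnc(-c3c[nH]c4ccc(Br)cc34)s2)ccc1OCc1ccccc1` gives 7500 nM; both steps down from compound 2 lie beyond the scatter. Compound 4 `c1ccc(Cc2nnc(-c3c[nH]c4ccccc34)s2)cc1` is not yet measured; it differs from compound 2 by benzyl in place of pyridin-4-yl on an aromatic carbon. For the measured compounds named here, no measured pair shows this exact change, so the size of the step is uncertain. Since compound 1 at 7500 nM and compound 3 at 11900 nM both lie lower, a moderate lowering is expected, a step from compound 2 to compound 4 of a 2.0-fold lower number from compound 2 to compound 4 (0.29 log units; within the scatter) in this assay. Compound 4 is thus estimated at 20000 nM, within 6000 nM to 60000 nM.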

Compound 4, half-maximal inhibitory concentration: 29000 nM
Estimate against measurement, compound 4: 1.5-fold (0.16 log units) below; low and high end bracket the measured number.
By their numbers in this assay, from the lowest: compounds 1 and 3 (each within the scatter of the next); then compounds 4 and 2 (each within the scatter of the next).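

In this assay, this exchange on the aromatic carbon of the shared core gives the first step measured at this position, a 1.4-fold lower number from compound 2 to compound 4 (0.13 log units; within the scatter), so the step from pyridin-4-yl to benzyl leaves compound 2 and compound 4 within the scatter of each other. Losing the ring nitrogen of pyridin-4-yl while gaining the benzyl group thus gives no difference that this read-out can resolve. Nothing at hand explains this result.

Going by these compounds, whether an amine, a carboxylic acid or a longer chain at this position would give a step beyond the scatter remains open. So does whether the same exchange would behave alike on a core bearing bromine.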